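Swapping Nitro for Acetamido on Two Shared Cores

A few compounds are considered here, and "the series" means these few. Any claim that something is new, unique, unknown or untested is made for them only; others in the source may bear on it.

Compound 1, `O=[N+]([O-])c1ccc(-c2nc3cc(C(F)(F)F)ccc3[nH]2)cc1`: 6000 nM
Compound 2, `CC(=O)Nc1ccc(-c2nc3cc(C(F)(F)F)ccc3[nH]2)cc1`: 50000 nM
Compound 3, `O=[N+]([O-])c1ccc(-c2nc3cc(Cl)c(Cl)cc3[nH]2)cc1`: 56000 nM

All three were tested in an ADME assay on MDBK cells (Bos taurus) for cytotoxicity, read by MTT assay, with a stated time of 96 h; a lower number here means that less compound is tolerated, a higher number that more compound is tolerated. Compound 2 differs from compound 1 by acetamido in place of nitro on an aromatic carbon, and this change gave an 8.3-fold higher number from compound 1 to compound 2 (0.92 log units; beyond the scatter). Compound 3 keeps the nitro group on a different core; the difference between the two cores is not broken down here. Compound 4, `CC(=O)Nc1ccc(-c2nc3cc(Cl)c(Cl)cc3[nH]2)cc1`, is not yet measured and differs from compound 3 by acetamido in place of nitro on an aromatic carbon, the same change seen from compound 1 to compound 2. Compound 4 is therefore expected to give a higher number than compound 3, resting on an 8.3-fold higher number from compound 1 to compound 2 (0.92 log units; beyond the scatter), though the starting number of compound 3 is already high and the assay may report only a limit. Compound 4 is estimated at 150000 nM, between 50000 nM and 500000 nM, an expected step of a 2.7-fold higher number from compound 3 to compound 4 (0.43 log units; beyond the scatter).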

Compound 4, half-maximal cytotoxic concentration: 58000 nM
Compound 4: the middle estimate sits 2.6-fold (0.41 log units) above what was measured, and the stated range covers the measured number.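

The change of nitro to acetamido in this assay gave a 1.0-fold higher number from compound 3 to compound 4 (0.02 log units; within the scatter), so on this core the swap made no difference that can be told from scatter. The same change therefore did not carry over from one core to the other with the same size of step: the same change on two cores in this assay, an 8.3-fold higher number (0.92 log units; beyond the scatter) from compound 1 to compound 2 and a 1.0-fold higher number (0.02 log units; within the scatter) from compound 3 to compound 4, 8.0-fold (0.91 log units) apart, beyond the scatter of two such steps. This shows that, across these two pairs, the step depends on the core, but it does not show which part of the core is responsible or what the change would do on a third core.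

The compounds shown leave open what an amine or a carboxylic acid would give on that aromatic carbon. They also leave open how a core carrying a single chlorine would respond to the same change.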